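From Dichlorophenyl to Bromophenyl in a Narrow Cytotoxicity Series

The source may report more compounds than this note shows. Statements on the series, on what has been measured and on what is new or still open speak of the compounds shown alone.

In a functional assay on HepG2 cells (Homo sapiens) for cytotoxicity, read by MTT assay, with a stated time of 72 h (on this read-out higher numbers stand for weaker inhibition and lower numbers for stronger inhibition), compound 1 (`CNC(=O)c1cc(Oc2ccc(C3=NNC(c4ccc(C#N)cc4)C3)cc2)ccn1`) gives 15000 nM, compound 2 (`CNC(=O)c1cc(Oc2ccc(C3=NNC(c4cccc([N+](=O)[O-])c4)C3)cc2)ccn1`) gives 26500 nM and compound 3 (`CNC(=O)c1cc(Oc2ccc(C3=NNC(c4ccc(Cl)c(Cl)c4)C3)cc2)ccn1`) gives 14400 nM. These three compounds share one core and differ only in the group on a saturated ring carbon. Compound 3 stands level with the other two, since its measured steps are a 1.0-fold lower number from compound 1 to compound 3 (0.02 log units; within the scatter) and a 1.8-fold lower number from compound 2 to compound 3 (0.26 log units; within the scatter), both within the scatter. The remaining step, a 1.8-fold higher number from compound 1 to compound 2 (0.25 log units; within the scatter), is also within the scatter.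

Compound 4 (`CNC(=O)c1cc(Oc2ccc(C3=NNC(c4ccc(Br)cc4)C3)cc2)ccn1`) has not yet been measured. It places 4-bromophenyl in that same position in place of 3,4-dichlorophenyl, on a saturated ring carbon: 4-bromophenyl in place of 3,4-dichlorophenyl on a saturated ring carbon. The three measured steps are the closest guide, and none of them leaves the scatter, so no step beyond the scatter is expected in this assay. The expected result is a 1.1-fold higher number from compound 3 to compound 4 (0.05 log units; within the scatter), which would lie within the scatter. The estimated value for compound 4 is 16000 nM, with an expected range from 8000 nM to 32000 nM.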

Compound 4, half-maximal inhibitory concentration: 57600 nM
Compound 4: the middle estimate sits 3.6-fold (0.56 log units) below what was measured, outside the stated range (above it).
By their numbers in this assay, from the lowest: compounds 3, 1 and 2 (each within the scatter of the next); then compound 4.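

This position is less flat than the first three compounds suggested. In this assay, 4-bromophenyl in place of 3,4-dichlorophenyl gives a 4.0-fold higher number from compound 3 to compound 4 (0.60 log units; beyond the scatter), and the other two comparisons agree, with a 3.8-fold higher number from compound 1 to compound 4 (0.58 log units; beyond the scatter) and a 2.2-fold higher number from compound 2 to compound 4 (0.34 log units; beyond the scatter), so this compound stands apart from all three as the weakest of the set. No measurement here bears on why this swap of one halogen-bearing phenyl group for another matters.

All four groups shown are substituted phenyl rings, so it remains open how an amine or a carboxylic acid would behave on this saturated ring carbon. A phenyl ring bearing a single chlorine could also help show whether the shift follows the kind of halogen or the number of halogens.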